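The source may report more compounds than this note shows. Statements on the series, on what has been measured and on what is new or still open speak of the compounds shown alone.

Three members of the series carry numbers in an assay on isolated protein for inhibition of Amine oxidase [flavin-containing] A (Homo sapiens), read by fluorescence and Amplex Red, with a stated time of 30 min; a higher number here means a weaker inhibitor, a lower number a stronger inhibitor. Compound 1 `CCCCNc1nnc(SCC(=O)N(Cc2cccc([N+](=O)[O-])c2)c2ccc(F)cc2)s1` gives 1180 nM in this assay. Compound 2 `COCCNc1nnc(SCC(=O)N(Cc2cccc([N+](=O)[O-])c2)c2ccc(F)cc2)s1` gives 60 nM in this assay. Compound 3 `CC(C)Nc1nnc(SCC(=O)N(Cc2cccc([N+](=O)[O-])c2)c2ccc(F)cc2)s1` gives 1070 nM in this assay. Compound 3 stands at the second highest of the three numbers, close to compound 1 and far from compound 2: an 18-fold higher number from compound 2 to compound 3 (1.25 log units; beyond the scatter).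

Compound 4 `CCNc1nnc(SCC(=O)N(Cc2cccc([N+](=O)[O-])c2)c2ccc(F)cc2)s1` differs from compound 3 by hydrogen in place of methyl on a saturated chain carbon bound to a nitrogen on an aromatic ring and a saturated chain carbon. Among the measured compounds shown here, one measured step bears directly on this change: a 1.1-fold lower number from compound 1 to compound 3 (0.04 log units; within the scatter), a swap of one plain alkyl group on the ring nitrogen for another, the same kind of change as here. The large steps are of a different kind. The first of them brings in a methoxy group: a 20-fold lower number from compound 1 to compound 2 (1.29 log units; beyond the scatter). The second, from compound 2 to compound 3, takes that methoxy group away again. Neither says anything about a shortening of a plain alkyl chain. No step beyond the scatter is therefore expected in this assay for compound 4. Compound 4 is expected to give 1000 nM in this assay, estimated between 400 nM and 2500 nM, which amounts to an expected 1.1-fold lower number from compound 3 to compound 4 (0.03 log units; within the scatter).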

Compound 4, half-maximal inhibitory concentration: 336 nM
Estimate against measurement, compound 4: 3.0-fold (0.47 log units) above; measured number outside the range, below it.
By their numbers in this assay, from the lowest: compound 2; then compound 4; then compounds 3 and 1 (each within the scatter of the next).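

In this assay, the plain alkyl groups on the nitrogen are not interchangeable: ethyl separates from isopropyl (a 3.2-fold lower number from compound 3 to compound 4 (0.50 log units; beyond the scatter)) and from butyl (a 3.5-fold lower number from compound 1 to compound 4 (0.55 log units; beyond the scatter)), although isopropyl and butyl lie within the scatter of each other. The methoxy group keeps its place at the end of the chain (a 5.6-fold higher number from compound 2 to compound 4 (0.75 log units; beyond the scatter)), so the ethylamino group of compound 4 does not match the 2-methoxyethyl group of compound 2, and removing the isopropyl methyl accounts for only part of the distance to compound 2. Nothing at hand gives a reason for either difference.

Open, going by these compounds, is how a methyl group or a bare amine on the nitrogen would compare with ethyl. Also open, on these data alone, is whether the low number of compound 2 survives with a hydroxyl in place of the methoxy group or with a longer ether chain.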